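This account rests on a few compounds, and the source may have more. Where it says the series, first, only, none or still open, it means among the compounds named here.

Measured compounds in the series:
compound 1 `CC(=O)Nc1ccc(S(=O)(=O)Nc2cccc(-c3nc(-c4ccc(NC(=O)c5cccnc5)cc4Cl)no3)c2)cc1`: 2500 nM
compound 2 `CC(=O)Nc1ccc(S(=O)(=O)Nc2cccc(-c3nc(-c4ccc(NC(=O)c5cccnc5)cc4)no3)c2)cc1`: 5200 nM
compound 3 `CC(=O)Nc1ccc(S(=O)(=O)Nc2cccc(-c3nc(-c4ccc(NC(=O)c5cccnc5)c(Cl)c4)no3)c2)cc1`: 4500 nM

In a functional assay on MDA-MB-231 cells (Homo sapiens) for antiproliferative activity, read by MTT assay, with a stated time of 72 h (a higher number here means a weaker inhibitor, a lower number a stronger inhibitor), compound 2 gives the highest of the three numbers. Compound 3 sits nearest, and the step of a 1.2-fold lower number from compound 2 to compound 3 (0.06 log units; within the scatter) lies within the scatter, so no order between compound 2 and compound 3 can be read. Compound 1 lies furthest off, and the step of a 2.1-fold higher number from compound 1 to compound 2 (0.32 log units; beyond the scatter) is modest but beyond the scatter.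

Compound 4 `COc1cc(NC(=O)c2cccnc2)ccc1-c1noc(-c2cccc(NS(=O)(=O)c3ccc(NC(C)=O)cc3)c2)n1` differs from compound 2 by methoxy in place of hydrogen on an aromatic carbon. Both measured steps concern a substituent on the same carbon-only aromatic ring, but each of them places a chloro group, not a methoxy group, and only one of the two registers beyond the scatter. Nothing here reports a methoxy group at any position, so the step from compound 2 to compound 4 in this assay can only be bracketed loosely: at most a modest movement, and more probably a lower number than a higher one, given that compound 2 is the highest of the three.

Compound 4 is therefore expected at 3500 nM, with a range of 1800 nM to 7000 nM, which amounts to an estimated step of a 1.5-fold lower number from compound 2 to compound 4 (0.17 log units; within the scatter).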

Compound 4, half-maximal inhibitory concentration: > 10000 nM
Compound 4 ended at the assay's limit (the forecaster's own chance of this, stated with the estimate: 5%); middle value at least 2.8-fold (0.45 log units) from the limit.
By their numbers in this assay, from the lowest: compounds 1, 3 and 2 (each within the scatter of the next, the first and the last beyond it). At a limit, above all of these: compound 4.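

In this assay compound 4 gives no number, only a limit of the assay: the limit of > 10000 nM in this assay, at which 1 of the 4 values shown sits.

On this same carbon, ortho to a large group, the identity of the substituent now matters: exchanging the chloro group of compound 1 for methoxy gives an at least 4.0-fold higher number from compound 1 to compound 4 (0.60 log units; beyond the scatter), so the earlier result for chloro does not carry over to every group placed here. Against hydrogen the reading is weaker, with an at least 1.9-fold higher number from compound 2 to compound 4 (0.28 log units; that floor lies within the scatter), and since that floor lies within the scatter, methoxy cannot yet be said to differ from hydrogen at this carbon, even though the limit leaves room for a larger step.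

As far as these compounds go, the true value of compound 4 past the limit stays open, and with it the full size of both steps. Also open, from the compounds shown here alone, is where a methyl group, a hydroxyl group, an amine or a longer chain such as ethoxy on this carbon would fall relative to chloro and methoxy, and whether methoxy on the carbon that carries chloro in compound 3 would behave in the same way.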